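Swapping the aromatic substituent: triazole in place of piperazinyl carbonyl

The source may hold more compounds than are shown below. What is called first, only, known or untested is meant among the compounds shown, and "the series" means these compounds.

Measured so far in an assay on isolated protein for inhibition of serine/threonine-protein kinase TBK1 (Homo sapiens); a higher number here means a weaker inhibitor, a lower number a stronger inhibitor:
Compound 1 `O=C(NCCCNc1nc(Nc2cnn(C3CCOCC3)c2)ncc1C1CC1)C1CCC1`: 2 nM
Compound 2 `CN(C)Cc1ccc(Nc2ncc(C3CC3)c(NCCCNC(=O)C3CCC3)n2)cc1`: 6 nM
Compound 3 `CN1CCN(C(=O)c2ccc(Nc3ncc(C4CC4)c(NCCCNC(=O)C4CCC4)n3)cc2)CC1`: 2 nM

Compound 3 shares the lowest numbers with compound 1, which it matches at the digits shown, while compound 2 sits higher, the step from compound 2 to compound 3 being a 3.0-fold lower number from compound 2 to compound 3 (0.48 log units; beyond the scatter). Compound 4 `O=C(NCCCNc1nc(Nc2ccc(-n3cncn3)cc2)ncc1C1CC1)C1CCC1` carries the change (1H-1,2,4-triazol-1-yl in place of (4-methylpiperazin-1-yl)carbonyl on an aromatic carbon). Among the compounds with values here, the only measured step bearing on this position is the one from compound 2 to compound 3, a modest one, and compound 1 with a quite different group here reaches the same low number as compound 3, so variation on this aromatic carbon has so far cost little. For compound 4 a small step, if any, is therefore expected, a 2.0-fold higher number from compound 3 to compound 4 (0.30 log units; within the scatter), and its estimated value is 4 nM with a range from 1.5 nM to 12 nM.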

Compound 4, half-maximal inhibitory concentration: 3 nM
Compound 4: middle estimate off by 1.3-fold (0.12 log units), on the high side, within the range that was stated.
By their numbers in this assay, from the lowest: compounds 1, 3, 4 and 2 (each within the scatter of the next, the first and the last beyond it).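

In this assay, 1H-1,2,4-triazol-1-yl on this aromatic carbon reads alike to the larger (4-methylpiperazin-1-yl)carbonyl (a 1.5-fold higher number from compound 3 to compound 4 (0.18 log units; within the scatter)) and to (dimethylamino)methyl (a 2.0-fold lower number from compound 2 to compound 4 (0.30 log units; within the scatter)). This shows that neither the six-membered non-aromatic ring nor the carbonyl is needed here, since a five-membered aromatic ring with no such parts stays within the scatter of both. Nothing available explains why these groups read alike. Still open, as far as these compounds go, is whether a carboxylic acid, a primary amine or a longer chain ending in morpholine would be tolerated on this carbon as well.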